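Amide-type nitrogen substituents: tert-butyl to allyl

The compounds below may be only part of what the source reports. "The series", "measured", "known", "first", "only" and "open" are said of these compounds alone.

Measured in a functional assay on FM3A cells (Mus musculus) for inhibition; on this read-out lower numbers stand for stronger inhibition and higher numbers for weaker inhibition:
- compound 1 `C/C(=C\COC(=O)Nc1ccccc1)C1=CC(=O)C(C)(C)O1`: > 200 ug/mL (a limit)
- compound 2 `C/C(=C\COC(=O)NC(C)(C)C)C1=CC(=O)C(C)(C)O1`: 7.1 ug/mL

Compound 1 gives no number, only a limit: the limit of > 200 ug/mL in this assay, at which 1 of the 2 values shown sits. Going by the values given here, compound 2, at 7.1 ug/mL, therefore holds the only actual number. The next compound is compound 3 `C=CCNC(=O)OC/C=C(\C)C1=CC(=O)C(C)(C)O1`, with allyl in place of tert-butyl on an amide-type nitrogen. Among the compounds with values here, one measured step bears on this nitrogen: an at least 28-fold lower number from compound 1 to compound 2 (1.44 log units; beyond the scatter), large and beyond the scatter, with tert-butyl in place of phenyl. Allyl, like tert-butyl, has no ring, so a change as large as that step is not expected here. A modest move towards a higher number in this assay is expected, given as a 2.1-fold higher number from compound 2 to compound 3 (0.32 log units; beyond the scatter). For compound 3 the estimate is 15 ug/mL, with an expected range of 4 ug/mL to 70 ug/mL.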

Compound 3, half-maximal inhibitory concentration: 7.6 ug/mL
Compound 3: middle estimate off by 2.0-fold (0.30 log units), on the high side, within the range that was stated.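

In this assay, allyl and tert-butyl on the amide-type nitrogen cannot be told apart, with a 1.1-fold higher number from compound 2 to compound 3 (0.03 log units; within the scatter), so within these two groups neither the branching of tert-butyl nor the double bond of allyl registers at this position. The large gap to phenyl recurs with a second group that has no ring, as an at least 26-fold lower number from compound 1 to compound 3 (1.42 log units; beyond the scatter). Compound 1 carries a limit and not a number, so this step and the earlier one from phenyl are bounds and not sizes: the limit of > 200 ug/mL in this assay, at which 1 of the 3 values shown sits.

Open, from the compounds shown here alone, is whether the gap belongs to any ring on this nitrogen or to phenyl alone, which cyclohexyl or benzyl would separate. Also open, going by these compounds, is how far the nitrogen tolerates a longer chain such as n-octyl, or a chain ending in a carboxylic acid or an amine.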